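The compounds below may be only part of what the source reports. "The series", "measured", "known", "first", "only" and "open" are said of these compounds alone.

Compound 1 `Cc1cc(C(=O)Nc2c(F)cccc2F)nn1Cc1cc(Cl)ccc1OCc1ccccc1`: 10 nM. Compound 2 `Cc1cc(C(N)=O)nn1Cc1cc(Cl)ccc1OCC(C)C`: 126 nM.

In an assay on CHO-K1 cells for displacement of a labelled ligand from prostaglandin E2 receptor EP1 subtype (Homo sapiens) (on this read-out lower numbers stand for stronger inhibition and higher numbers for weaker inhibition), compound 1 stands at the lowest of the two numbers shown, and the gap up to compound 2 lies beyond the scatter of repeated measurements. Compound 3 `Cc1cc(NC(=O)C2CCOC2)nn1Cc1cc(Cl)ccc1OCc1ccccc1` has not yet been measured in this assay. It differs from compound 1 in one place: ((oxolan-3-yl)carbonyl)amino in place of (2,6-difluorophenyl)carbamoyl on an aromatic carbon. Among the measured compounds shown here, no step between measured compounds that share this change has been recorded. A rise toward weaker inhibition, beyond the scatter, is expected, because compound 1 at 10 nM carries the group that leaves. The expected step is a 20-fold higher number from compound 1 to compound 3 (1.30 log units; beyond the scatter). Compound 3 is estimated at 200 nM, in the range 40 nM to 1000 nM.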

Compound 3, half-maximal inhibitory concentration: 39.8 nM
Estimate against measurement, compound 3: 5.0-fold (0.70 log units) above, and the stated range ends above it.
By their numbers in this assay, from the lowest: compound 1; then compound 3; then compound 2.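

The aromatic carbon of compound 1 tolerates the loss of the whole (2,6-difluorophenyl)carbamoyl group with only a modest change in this assay (a 4.0-fold higher number from compound 1 to compound 3 (0.60 log units; beyond the scatter)). The six-membered aromatic ring is therefore not needed to keep compound 3 at 39.8 nM, since a non-aromatic oxolane ring stands in its place. The change also puts the amide nitrogen, not the carbonyl, on the ring carbon, and nothing measured explains the size of this step.

Whether the ring or the amide direction accounts for the step stays open. So does how a carboxylic acid or an acetylamino group would read at this carbon.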